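The source may report more compounds than this note shows. Statements on the series, on what has been measured and on what is new or still open speak of the compounds shown alone.

In a functional assay on B16-F10 cells (Mus musculus) for antiproliferative activity, read by MTT assay, with a stated time of 48 h (on this read-out higher numbers stand for weaker inhibition and lower numbers for stronger inhibition), compound 1 `COc1ccc(/C=C/c2cc(OC)cc(OC)c2/C=C/C(=O)c2cccc(Br)c2)cc1` gives 5.1 ug/mL and compound 2 `COc1ccc(/C=C/c2cc(OC)cc(OC)c2/C=C/C(=O)c2ccc(Br)cc2)cc1` gives 6.5 ug/mL with a 1.3-fold higher number from compound 1 to compound 2 (0.11 log units; within the scatter) as the step between them. Compound 3 `COc1ccc(/C=C/c2cc(OC)cc(OC)c2/C=C/C(=O)c2ccc(N)cc2)cc1` gives 2.8 ug/mL and stands apart from only one of the others: a 1.8-fold lower number from compound 1 to compound 3 (0.26 log units; within the scatter) is a small step, whereas a 2.3-fold lower number from compound 2 to compound 3 (0.37 log units; beyond the scatter) is a modest one. Compound 4 `COc1ccc(/C=C/c2cc(OC)cc(OC)c2/C=C/C(=O)c2ccc(F)cc2)cc1` differs from compound 3 at one place fluoro in place of amino on an aromatic carbon with fluoro in place of amino on an aromatic carbon. Among the compounds with values here, no fluoro compound has been measured, so the nearest guide is compound 2 with its bromo group (a 2.3-fold lower number from compound 2 to compound 3 (0.37 log units; beyond the scatter)). The expected change in this assay is thus that modest step in reverse, a rise (a 1.8-fold higher number from compound 3 to compound 4 (0.25 log units; within the scatter)). Compound 4 is expected to give 5 ug/mL with 2.5 ug/mL to 10 ug/mL as the estimated range of the value.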

Compound 4, half-maximal inhibitory concentration: 5.3 ug/mL
The estimate for compound 4 lay 1.1-fold (0.03 log units) below the measured number; the measured number falls inside the stated range.
By their numbers in this assay, from the lowest: compounds 3, 1, 4 and 2 (each within the scatter of the next, the first and the last beyond it).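

In this assay, fluoro on this aromatic carbon cannot be separated from amino (a 1.9-fold higher number from compound 3 to compound 4 (0.28 log units; within the scatter)) or from bromo (a 1.2-fold lower number from compound 2 to compound 4 (0.09 log units; within the scatter)), so compound 4 sits inside the scatter of both ends of the one gap that exceeds it, that between compound 2 and compound 3. The 4-fluorophenyl group also matches the 3-bromophenyl group (a 1.0-fold higher number from compound 1 to compound 4 (0.02 log units; within the scatter)). Nothing on hand accounts for these steps. As far as these compounds go, whether a hydroxyl, a methoxy or a dimethylamino group at this place would go beyond the scatter from amino remains open, as does the effect of moving amino to the position bromo holds in compound 1.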